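Chloro for Methoxy on the Styryl Ring of a Chromenone Chalcone

A few compounds are considered here, and "the series" means these few. Any claim that something is new, unique, unknown or untested is made for them only; others in the source may bear on it.

The account follows compound 1 `COc1cccc(/C=C/C(=O)c2ccc(OC)c3c2OC(C)(C)C=C3)c1` toward compound 4 `COc1ccc(C(=O)/C=C/c2ccc(Cl)cc2)c2c1C=CC(C)(C)O2` in a functional assay on HCT-116 cells (Homo sapiens) for antiproliferative activity, read by MTT assay, with a stated time of 24 h; a lower number here means a stronger inhibitor, a higher number a weaker inhibitor. In this assay compound 1 gives only a limit, > 10000 nM, and no number. Among the three measured values, (the limit of > 10000 nM in this assay, at which 1 of the 3 values shown sits), so compound 1 stands at the weak end of what is known. The change is 4-chlorophenyl in place of 3-methoxyphenyl on a double-bonded chain carbon bound to a double-bonded chain carbon. For the measured compounds named here, only one measured step touches the same place: an at least 1.5-fold lower number from compound 1 to compound 3 (0.17 log units; that floor lies within the scatter), where compound 3 `COc1ccc(C(=O)/C=C/c2ccccn2)c2c1C=CC(C)(C)O2` gives 6630 nM in this assay. Going by the values given here, compound 2 `CCN(CC)c1ccc(/C=C/C(=O)c2ccc(OC)c3c2OC(C)(C)C=C3)cc1`, with diethylamino on the aryl group, gives 620 nM in this assay, but no single-place step links it to compound 1. Among the compounds with values here, since the one relevant step barely clears the scatter, a modest move toward a lower number is expected for compound 4, with a real chance that the limit is met again. Compound 4 is estimated at 5000 nM, spanning 1500 nM to 20000 nM, an expected step of an at least 2.0-fold lower number from compound 1 to compound 4 (0.30 log units; that floor lies within the scatter).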

Compound 4, half-maximal inhibitory concentration: > 10000 nM
Compound 4 gave a limit, no number; the forecaster's own chance of this, stated with the estimate: 35%; middle value at least 2.0-fold (0.30 log units) away from the limit.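

At this place on the double-bonded chain carbon, 4-chlorophenyl does not move the series off the limit of this assay, and with compound 1 and compound 4 both standing as limits, the step between them cannot be read: the limit of > 10000 nM in this assay, at which 2 of the 4 values shown sit.

Set against pyridin-2-yl, 4-chlorophenyl gives an at least 1.5-fold higher number from compound 3 to compound 4 (0.17 log units; that floor lies within the scatter), so the result does not separate these two groups. For the compounds shown here, the one large step is an at least 16-fold higher number from compound 2 to compound 4 (1.20 log units; beyond the scatter), which shows that a group on that aromatic carbon does not by itself give a low number, since diethylamino does and chloro does not.

The compounds shown leave open whether a smaller amine such as dimethylamino, or a ring amine such as morpholine, on the same aromatic carbon would keep the value of compound 2. They also leave open how a carboxylic acid there would read.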